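A few compounds are considered here, and "the series" means these few. Any claim that something is new, unique, unknown or untested is made for them only; others in the source may bear on it.

Measured compounds:
compound 1, `O=c1[nH]cc(S(=O)(=O)Nc2ccccc2-c2cn(-c3cccc(F)c3)nn2)c(=O)[nH]1`: "not toxic" (no number reported)
compound 2, `Cc1cccc(-n2cc(-c3cccc(NS(=O)(=O)c4c[nH]c(=O)[nH]c4=O)c3)nn2)c1`: 28300 nM

Among the compounds with values here, in an ADME assay on L02 cells (Homo sapiens) for cytotoxicity, read by MTT assay, with a stated time of 24 h (on this read-out higher numbers stand for lower toxicity in this test and lower numbers for higher toxicity in this test), compound 2 gives 28300 nM, the only number reported here, since compound 1 is described without a figure. Compound 3, `O=c1[nH]cc(S(=O)(=O)Nc2cccc(-c3cn(-c4ccc(Cl)cc4)nn3)c2)c(=O)[nH]1`, is not yet measured. It differs from compound 2 in one place: 4-chlorophenyl in place of 3-methylphenyl on an aromatic nitrogen. No comparable change has been measured, so nothing shows which way such a swap moves the read-out; the expected step of a 1.0-fold lower number from compound 2 to compound 3 (0.00 log units; within the scatter) is none beyond the usual scatter. Compound 3 is therefore estimated at 28000 nM, between 10000 nM and 80000 nM.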

Compound 3, half-maximal cytotoxic concentration: 9860 nM
The estimate for compound 3 lay 2.8-fold (0.45 log units) above the measured number; measured number outside the range, below it.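

In this assay, 4-chlorophenyl in place of 3-methylphenyl on an aromatic nitrogen gives a 2.9-fold lower number from compound 2 to compound 3 (0.46 log units; beyond the scatter). This shows that the group at this position is not neutral for the read-out: this single change moves it towards higher toxicity in this test. Nothing measured here explains the shift. This single step cannot separate the effect of adding the chlorine from that of losing the methyl. Going by these compounds, whether a phenyl carrying an amine or a carboxylic acid at this position would move the number the same way also remains open.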